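A few compounds are considered here, and "the series" means these few. Any claim that something is new, unique, unknown or untested is made for them only; others in the source may bear on it.

In a functional assay on DLD-1 cells (Homo sapiens) for cytotoxicity, read by WST assay, with a stated time of 72 h (on this read-out lower numbers stand for stronger inhibition and higher numbers for weaker inhibition), compound 1 `CCN(CC)CCCOc1cc2ncnc(Nc3nc4ccc(C(=O)Nc5c(C)cccc5C)cc4s3)c2cc1OC` gives only a limit, > 100000 nM, because it sits at the limit of > 100000 nM in this assay, at which 1 of the 3 values shown sits. Two related compounds carry a chloro group instead of one methyl: compound 3 `CCN(CC)CCCOc1cc2ncnc(Nc3nc4ccc(C(=O)Nc5c(C)cccc5Cl)cc4s3)c2cc1OC` gives 11700 nM, and compound 2 `COc1cc2c(Nc3nc4ccc(C(=O)Nc5c(C)cccc5Cl)cc4s3)ncnc2cc1OCCCN1CCC(C)CC1` gives 11300 nM, both in this assay. The step of an at least 8.5-fold lower number from compound 1 to compound 3 (0.93 log units; beyond the scatter) shows that swapping methyl for chloro matters, whereas a 1.0-fold higher number from compound 2 to compound 3 (0.02 log units; within the scatter) shows that changing the amine at the end of the chain does not. Compound 4 `COc1cc2c(Nc3nc4ccc(C(=O)Nc5c(C)cccc5C)cc4s3)ncnc2cc1OCCCN1CCCCC1` differs from compound 1 by piperidin-1-yl in place of diethylamino on a saturated chain carbon, three bonds along the chain from an oxygen on an aromatic ring, the same kind of amine exchange. Among the compounds with values here, only the step from compound 2 to compound 3 bears on it, and it lay within the scatter, so no step beyond the scatter is expected, a step that the limit leaves unreadable from compound 1 to compound 4. Compound 4 is therefore estimated at 150000 nM, between 50000 nM and 500000 nM, most likely again only a limit.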

Compound 4, half-maximal inhibitory concentration: > 100000 nM
Compound 4: only a limit was reported (the forecaster's own chance of this, stated with the estimate: 70%); the middle value does not contradict the limit.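

Within the data shown here, compound 1 and compound 4 both give only a limit in this assay, so no step between them can be read: the limit of > 100000 nM in this assay, at which 2 of the 4 values shown sit. The compounds shown leave open whether piperidin-1-yl in place of diethylamino changes the number at all.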